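Bromo to methyl on the benzoyl ring, second instance

The source may hold more compounds than are shown below. What is called first, only, known or untested is meant among the compounds shown, and "the series" means these compounds.

Of the compounds shown here, three of one series have been measured in an ADME assay on SH-SY5Y cells (Homo sapiens) for cytotoxicity, read by MTT assay, with a stated time of 72 h; a higher number here means a weaker inhibitor, a lower number a stronger inhibitor. Compound 1 `O=C(CN1CCN(C(=O)c2ccc(Br)cc2)CC1)N1CCN(CCCc2c[nH]c3ccc(F)cc23)CC1` gives 47400 nM. Compound 2 `Cc1ccc(C(=O)N2CCN(CC(=O)N3CCN(CCCc4c[nH]c5ccc(F)cc45)CC3)CC2)cc1` gives 119000 nM; the change from compound 1 is methyl in place of bromo on an aromatic carbon and the step is a 2.5-fold higher number from compound 1 to compound 2 (0.40 log units; beyond the scatter). Compound 3 `COc1ccc2[nH]cc(CCCN3CCN(C(=O)CN4CCN(C(=O)c5ccc(Br)cc5)CC4)CC3)c2c1` gives 150000 nM; it differs from compound 1 by methoxy in place of fluoro on an aromatic carbon, and the step is a 3.2-fold higher number from compound 1 to compound 3 (0.50 log units; beyond the scatter). The values of compound 2 and compound 3 lie within the scatter of each other.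

Compound 4 `COc1ccc2[nH]cc(CCCN3CCN(C(=O)CN4CCN(C(=O)c5ccc(C)cc5)CC4)CC3)c2c1` is not yet measured. It stands to compound 3 as compound 2 stands to compound 1: the change is methyl in place of bromo on an aromatic carbon, the same kind of change at a place described in the same words. For the measured compounds named here, only one earlier instance exists, so the expectation rests on that single step. In this assay, going by the values given here, the step from compound 3 to compound 4 is expected to be a 2.2-fold higher number from compound 3 to compound 4 (0.34 log units; beyond the scatter), set beside the earlier step because a 2.5-fold higher number from compound 1 to compound 2 (0.40 log units; beyond the scatter) is the sole guide. Compound 4 is therefore estimated at 330000 nM, with a range of 150000 nM to 700000 nM.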

Compound 4, half-maximal inhibitory concentration: > 200000 nM
Compound 4: no number, only a limit; the forecaster's own chance of this, stated with the estimate: 25%; the middle value is on the limit's open side.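

In this assay compound 4 gives > 200000 nM, which is a limit of the assay and not a number. On the core of compound 3, methyl in place of bromo reads as an at least 1.3-fold higher number from compound 3 to compound 4 (0.12 log units; that floor lies within the scatter), so the result does not go against the step on the core of compound 1, yet it does not show that the size of that step carries over: the same change on two cores in this assay, a 2.5-fold higher number (0.40 log units; beyond the scatter) from compound 1 to compound 2 and an at least 1.3-fold higher number (0.12 log units; that floor lies within the scatter) from compound 3 to compound 4; the limit leaves it open whether they differ. Methoxy in place of fluoro, read with methyl on the benzoyl ring, stands the same way as an at least 1.6-fold higher number from compound 2 to compound 4 (0.22 log units; that floor lies within the scatter), and its carry-over between cores remains equally unsettled: the same change on two cores in this assay, a 3.2-fold higher number (0.50 log units; beyond the scatter) from compound 1 to compound 3 and an at least 1.6-fold higher number (0.22 log units; that floor lies within the scatter) from compound 2 to compound 4; the limit leaves it open whether they differ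

The compounds shown hold only 4-bromophenyl and 4-methylphenyl at this place, with two instances of the change, so it remains open whether the pattern extends to a chloro group or an amine there. Also open, as far as these compounds go, is whether a longer chain elsewhere on the shared core would shift the values in this assay.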